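A few compounds are considered here, and "the series" means these few. Any claim that something is new, unique, unknown or untested is made for them only; others in the source may bear on it.

The compounds share one core, shown in compound 1 `CCCCn1cc(C(=O)NCc2ccccc2)c(=O)c2cc(F)c(-c3ccccc3)cc21`, which carries a butyl chain on the ring nitrogen, a fluoro group, a phenyl group and a benzylamide. In an ADME assay on J774.1 cells (Mus musculus) for cytotoxicity, read by resazurin assay, with a stated time of 48 h (a lower number here means a stronger inhibitor, a higher number a weaker inhibitor), compound 1 gives > 100000 nM, which is a limit of the assay rather than a measured number. Compound 2 `CCCn1cc(C(=O)O)c(=O)c2cc(F)c(Cl)cc21` carries a propyl chain, a free carboxylic acid and a chloro group on the same core. In this assay compound 2 gives > 100000 nM, again only a limit. Compound 3 `CCCCn1cc(C(=O)NCc2ccc([N+](=O)[O-])cc2)c(=O)c2cc(F)c(N3CCC(C(N)=O)CC3)cc21` carries a nitro group and a carbamoyl-bearing piperidine. In this assay compound 3 gives > 100000 nM, once more a limit. Compound 1 therefore stands with the other two at the limit of > 100000 nM in this assay, at which 3 of the 3 values shown sit, and nothing in the shown values sets any of the three apart, so no step between measured compounds can be stated.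

Compound 4 `CCCCn1cc(C(=O)NCc2ccccc2)c(=O)c2cc(F)c(N3CCCCC3)cc21` has not been measured. It differs from compound 1 by piperidin-1-yl in place of phenyl on an aromatic carbon. Because compound 1 gives > 100000 nM and every other shown value also rests at the limit, no move beyond the scatter is expected in this assay. The expected step is a number no higher from compound 1 to compound 4 (the limit leaves the size open), that is, none beyond the scatter. Compound 4 is estimated at 100000 nM, with a range from 50000 nM to 300000 nM, and most likely the assay will again report only a limit.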

Compound 4, half-maximal inhibitory concentration: 47800 nM
Estimate against measurement, compound 4: 2.1-fold (0.32 log units) above; the whole stated range lies above it.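

This position on the shared core, ortho to a fluoro group, proves not to be silent in this assay: piperidin-1-yl in place of phenyl gives an at least 2.0-fold lower number from compound 1 to compound 4 (0.32 log units; beyond the scatter). The earlier compounds shown here could not show this, as none of them gave a number that could be compared: the limit of > 100000 nM in this assay, at which 3 of the 4 values shown sit. The step starts from a limit, so it fixes only a lower bound on the size of the change, and it rests on this single pair of compounds.

Compound 3 also carries a piperidine-based group at this place, a carbamoyl-bearing one, but it differs from compound 4 in the benzylamide as well, so the pair cannot say whether the carbamoyl group or the nitro group matters here. Also open, as far as these compounds go, is whether the lower number is particular to piperidin-1-yl or also appears with a morpholine ring or a simple open-chain amine at this place, and whether it persists with a longer chain on the ring nitrogen or a carboxylic acid in place of the benzylamide.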